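Predicting a 3-bromophenyl analogue from three triazole amides

The source may report more compounds than this note shows. Statements on the series, on what has been measured and on what is new or still open speak of the compounds shown alone.

Compound 2 `Cc1ccc(-n2cc(CN3C(=O)C[C@@H]4CC[C@@]3(C)C4(C)C)nn2)cc1` gives 400 nM in a functional assay on A549 cells (Homo sapiens) for inhibition, read by MTT assay, with a stated time of 24 h (on this read-out lower numbers stand for stronger inhibition and higher numbers for weaker inhibition), the highest of the three numbers shown. Compound 1 `Cc1ccccc1-n1cc(CN2C(=O)C[C@@H]3CC[C@@]2(C)C3(C)C)nn1` gives 90 nM and compound 3 `CC1(C)[C@H]2CC[C@]1(C)N(Cc1cn(-c3ccccc3)nn1)C(=O)C2` gives 70 nM; the two are within the scatter of each other (a 1.3-fold lower number from compound 1 to compound 3 (0.11 log units; within the scatter)). The change to compound 4 `CC1(C)[C@H]2CC[C@]1(C)N(Cc1cn(-c3cccc(Br)c3)nn1)C(=O)C2` is 3-bromophenyl in place of 4-methylphenyl on an aromatic nitrogen. For the measured compounds named here, two steps bear on it: a 4.4-fold higher number from compound 1 to compound 2 (0.65 log units; beyond the scatter) and a 5.7-fold lower number from compound 2 to compound 3 (0.76 log units; beyond the scatter), both of which show that 4-methylphenyl goes with the weakest inhibition here. Going by these compounds, no 3-substituted phenyl has been measured, so the bromine itself is untested. The author therefore expects a modest step downward, a 3.3-fold lower number from compound 2 to compound 4 (0.52 log units; beyond the scatter), landing compound 4 near compounds 1 and 3. Compound 4 is estimated at 120 nM, with a range of 40 nM to 400 nM.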

Compound 4, half-maximal inhibitory concentration: 90 nM
Compound 4: the middle estimate sits 1.3-fold (0.12 log units) above what was measured; measured number inside the range.
By their numbers in this assay, from the lowest: compounds 3, 1 and 4 (each within the scatter of the next); then compound 2.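

The 3-bromophenyl group on the aromatic nitrogen gives a 4.4-fold lower number from compound 2 to compound 4 (0.65 log units; beyond the scatter), while a 1.3-fold higher number from compound 3 to compound 4 (0.11 log units; within the scatter) and no change at the digits printed from compound 1 to compound 4 (within the scatter), so this first 3-substituted phenyl falls in with the phenyl and 2-methylphenyl compounds. Of the four compounds, only compound 2, with 4-methylphenyl, stands apart from the others beyond the scatter. Nothing measured here accounts for that separation. Going by these compounds, whether 4-bromophenyl would go with the higher number, as 4-methylphenyl does, stays open, and so does how a phenyl carrying an amine or a carboxylic acid would read.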